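Swapping a Carboxy Group for a Hydroxycyclohexylamino Substituent

This account rests on a few compounds, and the source may have more. Where it says the series, first, only, none or still open, it means among the compounds named here.

Three measured compounds share one core and differ only in the group on a six-membered aromatic ring of carbon only. In an assay for inhibition of Tryptophan 2,3-dioxygenase (Homo sapiens), with stated times of 10 min and 60 min (a higher number here means a weaker inhibitor, a lower number a stronger inhibitor), compound 1 `O=[N+]([O-])c1cccc(CNc2cc(C(F)(F)F)cc3[nH]ncc23)c1` gives 5170 nM, compound 2 `FC(F)(F)c1cccc(CNc2cc(C(F)(F)F)cc3[nH]ncc23)c1` gives 12200 nM, and compound 3 `O=C(O)c1cccc(CNc2cc(C(F)(F)F)cc3[nH]ncc23)c1` gives 1690 nM, the lowest of the three numbers. Compound 4 `OC1CCCC(Nc2cccc(CNc3cc(C(F)(F)F)cc4[nH]ncc34)c2)C1` carries (3-hydroxycyclohexyl)amino in place of carboxy on an aromatic carbon. Among the compounds with values here, the steps bearing on this position are a 3.1-fold lower number from compound 1 to compound 3 (0.49 log units; beyond the scatter) and a 7.2-fold lower number from compound 2 to compound 3 (0.86 log units; beyond the scatter), and also a 2.4-fold higher number from compound 1 to compound 2 (0.37 log units; beyond the scatter), so the group here clearly matters, yet none of the measured groups resembles the entering one. The expected step is therefore a 2.1-fold higher number from compound 3 to compound 4 (0.32 log units; beyond the scatter), a modest rise with wide uncertainty. For compound 4 the estimate in this assay is 3500 nM, within a range from 800 nM to 15000 nM.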

Compound 4, half-maximal inhibitory concentration: > 100000 nM
Compound 4 ended at the assay's limit; the forecaster's own chance of this, stated with the estimate: 10%; middle value at least 28-fold (1.45 log units) away from the limit.
By their numbers in this assay, from the lowest: compound 3; then compound 1; then compound 2. At a limit, above all of these: compound 4.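

Compound 4 stands at a limit of the assay, not at a number: the limit of > 100000 nM in this assay, at which 1 of the 4 values shown sits. Even so, the steps show that this position does not accept every group, since the (3-hydroxycyclohexyl)amino group gives an at least 59-fold higher number from compound 3 to compound 4 (1.77 log units; beyond the scatter), as well as an at least 19-fold higher number from compound 1 to compound 4 (1.28 log units; beyond the scatter) and an at least 8.1-fold higher number from compound 2 to compound 4 (0.91 log units; beyond the scatter). It therefore falls behind carboxy, nitro and trifluoromethyl alike, a change of a different order from those among the earlier groups.

The compounds shown leave open whether the loss belongs to the ring, the hydroxy or the amino link. A plain amine or an unsubstituted cyclohexylamino group at this place would separate these.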